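The source may report more compounds than this note shows. Statements on the series, on what has been measured and on what is new or still open speak of the compounds shown alone.

Of the compounds shown here, three sharing one core have been tested in a functional assay on HepG2 cells (Homo sapiens) for antiproliferative activity, read by MTT assay, with a stated time of 48 h; on this read-out lower numbers stand for stronger inhibition and higher numbers for weaker inhibition. Compound 1 `O=c1cc(-c2ccccc2)oc2cc(O)c(OCCCN3CCCCC3)c(O)c12` gives 70600 nM. Compound 3 `CN1CCN(CCCCOc2c(O)cc3oc(-c4ccccc4)cc(=O)c3c2O)CC1` gives 93700 nM; against compound 1 the step is a 1.3-fold higher number from compound 1 to compound 3 (0.12 log units; within the scatter), which is within the scatter, so the two stand level. For compound 2 `O=c1cc(-c2ccccc2)oc2cc(O)c(OCCCCN3CCCCC3)c(O)c12` the assay reports only a limit, > 100000 nM. Compound 4 `O=c1cc(-c2ccccc2)oc2cc(O)c(OCCCCN3CCCC3)c(O)c12` differs from compound 3 by pyrrolidin-1-yl in place of 4-methylpiperazin-1-yl on a saturated chain carbon, four bonds along the chain from an oxygen on an aromatic ring. Among the compounds with values here, the one earlier change at that same position, an at least 1.0-fold lower number from compound 2 to compound 3 (0.02 log units; that floor lies within the scatter), stayed within the scatter, and the chain change an at least 1.4-fold higher number from compound 1 to compound 2 (0.15 log units; that floor lies within the scatter) did likewise, so another swap of the amine ring is expected to give a 1.0-fold lower number from compound 3 to compound 4 (0.02 log units; within the scatter), nothing beyond the scatter. Compound 4 is therefore estimated at 90000 nM, with a range from 40000 nM to 200000 nM.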

Compound 4, half-maximal inhibitory concentration: > 100000 nM
Compound 4 gave a limit, no number; the forecaster's own chance of this, stated with the estimate: 40%; at least 1.1-fold (0.04 log units) between middle value and limit.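

Replacing 4-methylpiperazin-1-yl with the smaller, five-membered pyrrolidin-1-yl gives an at least 1.0-fold higher number from compound 3 to compound 4 (0.02 log units; that floor lies within the scatter), while changing chain and ring together gives an at least 1.4-fold higher number from compound 1 to compound 4 (0.15 log units; that floor lies within the scatter), so neither step shows a real change. The step from compound 2 to compound 4 cannot be read, since both values are limits. A third amine ring at this position therefore brings no readable gain in inhibition, and the comparison now rests largely on a ceiling: the limit of > 100000 nM in this assay, at which 2 of the 4 values shown sit.

Going by these compounds, it remains open whether pyrrolidin-1-yl on the chain of compound 1 would give a readable number. The same applies to an open-chain amine such as dimethylamino.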